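From methyl to fluoro on compound 3

The compounds below may be only part of what the source reports. "The series", "measured", "known", "first", "only" and "open" are said of these compounds alone.

In an ADME assay on BHK-21 cells (Mesocricetus auratus) for cytotoxicity, read by MTT assay, with a stated time of 72 h (a higher number here means that more compound is tolerated, a lower number that less compound is tolerated), compound 3 `Cc1ccc(C2CC(c3ccc(Oc4ccccc4)cc3)=NN2c2ccc(S(N)(=O)=O)cc2)cc1` gives 8000 nM as its value, level with compound 1 `Cc1cccc(C2CC(c3ccc(Oc4ccccc4)cc3)=NN2c2ccc(S(N)(=O)=O)cc2)c1` at 8000 nM at the digits shown, while compound 2 `NS(=O)(=O)c1ccc(N2N=C(c3ccc(Oc4ccccc4)cc3)CC2c2cccc(F)c2)cc1` at 10000 nM sits within the scatter of both. On these numbers the three compounds cannot be told apart.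

Compound 4 `NS(=O)(=O)c1ccc(N2N=C(c3ccc(Oc4ccccc4)cc3)CC2c2ccc(F)cc2)cc1` departs from compound 3 in one group only. The change is fluoro in place of methyl on an aromatic carbon and it reads 4-methylphenyl to 4-fluorophenyl, with fluoro in place of methyl on an aromatic carbon. The closest evidence is the same exchange on another pair of compounds, which gave a 1.3-fold higher number from compound 1 to compound 2 (0.10 log units; within the scatter) as its result. Shifting the methyl group itself gave no change at the digits printed from compound 1 to compound 3 (within the scatter) and so also left the number in place. Neither step suggests a large move, so nothing beyond the scatter is expected in this assay and a 1.3-fold higher number from compound 3 to compound 4 (0.10 log units; within the scatter) is the estimated step. For compound 4 the expected value is 10000 nM with 5500 nM to 18000 nM as the estimated range.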

Compound 4, half-maximal cytotoxic concentration: 8000 nM
Estimate against measurement, compound 4: 1.3-fold (0.10 log units) above; the measured number falls inside the stated range.
By their numbers in this assay, from the lowest: compounds 1, 3, 4 and 2 (each within the scatter of the next).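

Fluoro in place of methyl on this ring, para to a large group, gives no change at the digits printed from compound 3 to compound 4 (within the scatter) in this assay, so the exchange now leaves the number within the scatter on a second pair of compounds: the same change on two cores in this assay, a 1.3-fold higher number (0.10 log units; within the scatter) from compound 1 to compound 2 and no change at the digits printed (within the scatter) from compound 3 to compound 4, 1.3-fold (0.10 log units) apart, within the scatter of two such steps

The new compound also shows that the place of the fluoro makes no readable difference, as 4-fluorophenyl in place of 3-fluorophenyl gives a 1.3-fold lower number from compound 2 to compound 4 (0.10 log units; within the scatter). Changing the group and its place together, 4-fluorophenyl in place of 3-methylphenyl, gives no change at the digits printed from compound 1 to compound 4 (within the scatter), so even this double change does not separate the compounds.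

The compounds shown carry only methyl or fluoro on this ring, so they leave open whether an amine, a carboxylic acid or a longer chain there would move the number beyond the scatter. They also give no reason why these four numbers lie so close together.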